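Exchanging methyl for 2,3-dihydroxyphenyl on compound 2

The compounds below may be only part of what the source reports. "The series", "measured", "known", "first", "only" and "open" are said of these compounds alone.

Going by the values given here, in a functional assay on RAW264.7 cells (Mus musculus) for inhibition (a lower number here means a stronger inhibitor, a higher number a weaker inhibitor), compound 2 `C=C[C@H]1[C@H](O[C@@H]2O[C@H](COC(C)=O)[C@@H](OC(C)=O)[C@H](O)[C@H]2OC(C)=O)OC=C2C(=O)OCC[C@H]21` gives 52800 nM, the only true number among the three measured compounds. Compound 1 `C=C[C@H]1[C@H](O[C@@H]2O[C@H](COC(C)=O)[C@@H](O)[C@H](OC(C)=O)[C@H]2OC(C)=O)OC=C2C(=O)OCC[C@H]21` reads > 200000 nM, which is a limit of the assay and not a number. Compound 3 `C=C[C@H]1[C@H](O[C@@H]2O[C@H](COC(C)=O)[C@@H](O)[C@H](OC(C)=O)[C@H]2OC(=O)c2cccc(O)c2O)OC=C2C(=O)OCC[C@H]21` reads > 200000 nM, which is also a limit.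

Compound 4 `C=C[C@H]1[C@H](O[C@@H]2O[C@H](COC(C)=O)[C@@H](OC(C)=O)[C@H](O)[C@H]2OC(=O)c2cccc(O)c2O)OC=C2C(=O)OCC[C@H]21` departs from compound 2 by one change: 2,3-dihydroxyphenyl in place of methyl on a carbonyl carbon. In words, this is 2,3-dihydroxyphenyl in place of methyl on a carbonyl carbon, and the same difference can be read as acetoxy to ((2,3-dihydroxyphenyl)carbonyl)oxy.

Among the compounds with values here, one measured step bears on it, the same kind of exchange: a step that the two limits leave unreadable from compound 1 to compound 3. Both of its ends rest on (the limit of > 200000 nM in this assay, at which 2 of the 3 values shown sit), so it offers no size and no direction to carry over. With nothing readable to transfer, no step beyond the scatter is expected in this assay, and compound 2 at 52800 nM remains the anchor for the expectation. The expected change is a 1.1-fold higher number from compound 2 to compound 4 (0.06 log units; within the scatter), held with little confidence in its direction. A result at the limit of the assay would not be surprising. For compound 4 the estimated value is 60000 nM, with an expected range from 18000 nM to 200000 nM.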

Compound 4, half-maximal inhibitory concentration: 690 nM
The estimate for compound 4 lay 87-fold (1.94 log units) above the measured number, outside the stated range (below it).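

In this assay the exchange of methyl for 2,3-dihydroxyphenyl on a carbonyl carbon now has a size and a direction, a 77-fold lower number from compound 2 to compound 4 (1.88 log units; beyond the scatter), and it is large. The earlier pair carrying the same exchange, compound 1 and compound 3, could show neither, because that step cannot be read with both of its ends resting on a limit: the limit of > 200000 nM in this assay, at which 2 of the 4 values shown sit. This single readable pair shows that the acetoxy group of compound 2 is not a fixed requirement at this place, since ((2,3-dihydroxyphenyl)carbonyl)oxy, which brings one six-membered aromatic ring and 2 hydrogen-bond donors, is far from being merely tolerated.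

The compounds shown leave open whether the gain belongs to the aromatic ring or to its two hydroxyl groups, since a plain phenyl, a 2-hydroxyphenyl or a 2,3-dimethoxyphenyl on the same carbonyl carbon does not appear among them. They also leave open whether a non-aromatic group such as cyclohexyl, or a longer chain such as hexyl, would move the number in the same direction.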